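The compounds below may be only part of what the source reports. "The series", "measured", "known", "first", "only" and "open" are said of these compounds alone.

Working notes on the series built around the shared core.

Compound 3 `COc1ccc(/C=C/C(=O)c2ccc(NC(=O)CN3CCN(c4cc5c(cc4F)c(=O)c(C(=O)O)cn5C4CC4)CC3)cc2)cc1OC` stands highest of the three numbers in a physicochemical assay for lipophilicity, using the shake flask method, in phosphate buffer, measured as octanol-water partition, with a stated time of 5 h; a lower number here means a more polar compound, a higher number a more lipophilic compound: compound 3 gives 1.46. Nearest to it is compound 2 `O=C(CN1CCN(c2cc3c(cc2F)c(=O)c(C(=O)O)cn3C2CC2)CC1)Nc1ccc(C(=O)/C=C/c2ccc(Cl)cc2)cc1`, which in this assay gives 0.471; furthest is compound 1 `O=C(CN1CCN(c2cc3c(cc2F)c(=O)c(C(=O)O)cn3C2CC2)CC1)Nc1ccc(C(=O)/C=C/c2cccc(Cl)c2)cc1`, which in this assay gives 0.302. The step of a number 0.99 log units higher from compound 2 to compound 3 (beyond the scatter) and the step of a number 1.16 log units higher from compound 1 to compound 3 (beyond the scatter) both lie beyond the scatter, whereas a number 0.17 log units higher from compound 1 to compound 2 (within the scatter) does not.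

Compound 4 `COc1cc(/C=C/C(=O)c2ccc(NC(=O)CN3CCN(c4cc5c(cc4F)c(=O)c(C(=O)O)cn5C4CC4)CC3)cc2)cc(OC)c1OC` has not been measured. Its difference from compound 3 is methoxy in place of hydrogen on an aromatic carbon; the same change, cut one bond further out, reads 3,4-dimethoxyphenyl to 3,4,5-trimethoxyphenyl. Among the measured compounds shown here, no measured step adds a single methoxy to a ring that already carries methoxy groups. For the measured compounds named here, the steps that bear on it are a number 1.16 log units higher from compound 1 to compound 3 (beyond the scatter) and a number 0.99 log units higher from compound 2 to compound 3 (beyond the scatter), in which the ring bringing in two methoxy groups gave higher numbers than either chlorophenyl ring. A third methoxy on the same ring is expected to move the number by less than either of those steps, upward if at all beyond the scatter; the expected step is a number 0.24 log units higher from compound 3 to compound 4 (within the scatter). Compound 4 is expected in this assay to give about 1.7, within a range of 1.2 to 2.3.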

Compound 4, partition coefficient: 0.753
Beside the measured number, compound 4's estimate is 0.95 log units above it, and the stated range ends above it.
By their numbers in this assay, from the lowest: compounds 1, 2 and 4 (each within the scatter of the next, the first and the last beyond it); then compound 3.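

In this assay, among the compounds shown here, methoxy in place of hydrogen on an aromatic carbon, ortho to one methoxy group and meta to another, gives a number 0.71 log units lower from compound 3 to compound 4 (beyond the scatter) and so shows that this ring position is not neutral to the read-out, which the earlier compounds could not show because none of them changed the methoxy count on a ring that already carried methoxy groups. For the compounds shown here, the higher numbers seen for 3,4-dimethoxyphenyl over both chlorophenyl rings therefore do not extend in a simple way to 3,4,5-trimethoxyphenyl: the step of a number 0.28 log units higher from compound 2 to compound 4 (within the scatter) stays inside the scatter, and only the step of a number 0.45 log units higher from compound 1 to compound 4 (beyond the scatter) lies outside it, and it is smaller than the corresponding steps to compound 3. No measurement offered here accounts for the fall on adding this methoxy group.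

The compounds shown leave open whether this step belongs to methoxy itself or to any group at this carbon, a question that a hydroxy group, an amine or a longer ethoxy chain in the same place would address. They also leave open where a ring with a single methoxy group would stand in this short sequence.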